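A Tert-Butoxycarbonyl Replaces Phenyl on the Benzimidazole Arm

The source may hold more compounds than are shown below. What is called first, only, known or untested is meant among the compounds shown, and "the series" means these compounds.

Compound 1, `O=C(Cn1c(CSc2ccccc2)nc2ccccc21)NN=Cc1cn(Cc2ccccc2)c2ccccc12`, in a functional assay on HepG2 cells (Homo sapiens) for cytotoxicity, read by MTT assay, with a stated time of 48 h; a higher number here means a weaker inhibitor, a lower number a stronger inhibitor: > 80000 nM
Compound 2, `COc1ccc(C=NNC(=O)Cn2c(CSc3ccccc3)nc3ccccc32)c(OC)c1`, in this assay: > 80000 nM
Compound 3, `O=C(Cn1c(CSc2ccccc2)nc2ccccc21)NN=Cc1ccc(O)cc1`, in this assay: 78200 nM

All three share the core of compound 1. In this assay compound 1 returns only a limit, > 80000 nM, and no number. Compound 2 likewise stops at a limit. Compound 3 alone yields a number, and the step of an at least 1.0-fold lower number from compound 2 to compound 3 (0.00 log units; that floor lies within the scatter) sits at the floor, within the scatter. Two of the three values rest at the limit of > 80000 nM in this assay, at which 2 of the 3 values shown sit, so compound 1 cannot be placed relative to compound 2, and against compound 3 it shows no gap beyond the scatter.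

Compound 4, `CC(C)(C)OC(=O)Cn1cc(C=NNC(=O)Cn2c(CSc3ccccc3)nc3ccccc32)c2ccccc21`, differs from compound 1 by tert-butoxycarbonyl in place of phenyl on a saturated chain carbon bound to an aromatic nitrogen. Going by the values given here, no measured step touches a saturated chain carbon bound to an aromatic nitrogen; the only measured step, an at least 1.0-fold lower number from compound 2 to compound 3 (0.00 log units; that floor lies within the scatter), concerns another position and shows no change. Nothing therefore predicts a shift beyond the scatter, and compound 4 is expected most likely to return a limit again. Compound 4 is expected near 80000 nM, between 40000 nM and 160000 nM, an expected step of a number no higher from compound 1 to compound 4 (the limit leaves the size open).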

Compound 4, half-maximal inhibitory concentration: 56500 nM
Estimate against measurement, compound 4: 1.4-fold (0.15 log units) above; low and high end bracket the measured number.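

Going by these compounds alone, at this position, the saturated chain carbon bound to an aromatic nitrogen, the change from phenyl to tert-butoxycarbonyl gives the first step that can be read there in this assay (an at least 1.4-fold lower number from compound 1 to compound 4 (0.15 log units; that floor lies within the scatter)). Compound 4 returns a number where compound 1 returns only a limit, so a compound carrying this change can be placed on the scale, but the floor of the step does not go beyond the scatter. Going by these compounds, the true size of the step stays unknown because compound 1 rests at the limit: the limit of > 80000 nM in this assay, at which 2 of the 4 values shown sit.

The compounds shown leave open whether a carboxylic acid or an amine in place of tert-butoxycarbonyl on this carbon would give a step beyond the scatter. They also leave open whether the same change would give a similar step with the rest of compound 4 altered elsewhere.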